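The compounds below may be only part of what the source reports. "The series", "measured", "known", "first", "only" and "open" are said of these compounds alone.

Measured so far in a functional assay on MCF7 cells (Homo sapiens) for antiproliferative activity, read by WST assay, with a stated time of 72 h; a lower number here means a stronger inhibitor, a higher number a weaker inhibitor:
Compound 1 `COc1ccc2[nH]c(-c3nc(-c4ccccc4)no3)cc2c1` gives > 50000 nM, which is a limit of the assay and not a number.
Compound 2 `COc1ccc(-c2noc(-c3cc4ccccc4[nH]3)n2)cc1` gives > 50000 nM, again a limit and not a number.

Where compound 2 stands: nothing in the series sits below the limit, so compound 2 has no measured rank within the set. Among the measured compounds shown here, the only evidence on potency is the limit of > 50000 nM in this assay, at which 2 of the 2 values shown sit; both measured values rest on it, and no step between measured compounds can be computed.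

The next compound is compound 3 `COc1ccc(-c2noc(-c3cc4cc(OC)ccc4[nH]3)n2)cc1`. It is compound 2 with methoxy in place of hydrogen on an aromatic carbon, so that compound 3 carries the methoxy groups of both compound 1 and compound 2 together on the shared core.

Expectation: with both parents at the limit, the step is expected to be none beyond the scatter, and most probably compound 3 is expected to return a limit as well; the estimated step from compound 2 to compound 3 in this assay is a step that the limit leaves unreadable from compound 2 to compound 3. Compound 3 is therefore estimated at 60000 nM, with a range from 20000 nM to 200000 nM.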

Compound 3, half-maximal inhibitory concentration: > 50000 nM
Compound 3: a limit, no number; the forecaster's own chance of this, stated with the estimate: 85%; the middle value is on the limit's open side.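

Compound 3 returns a limit and not a number, so neither the step from compound 1 nor the step from compound 2 to compound 3 can be read in this assay, because all three compounds rest on the same limit: the limit of > 50000 nM in this assay, at which 3 of the 3 values shown sit.

The compounds shown leave open whether any change to the shared core gives a measurable potency.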